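Adding a methoxy to compound 2

The compounds below may be only part of what the source reports. "The series", "measured", "known", "first", "only" and "open" are said of these compounds alone.

In a functional assay on A549 cells (Homo sapiens) for antiproliferative activity, read by MTT assay, with a stated time of 72 h (on this read-out lower numbers stand for stronger inhibition and higher numbers for weaker inhibition), compound 1 (`COc1cc(/C=C/C(=O)/C=C/c2nc(C)c(C)nc2C)ccc1O`) gives 2190 nM and compound 2 (`COc1ccc(/C=C/C(=O)/C=C/c2nc(C)c(C)nc2C)cc1OC`) gives 3790 nM so the two sit within the scatter of each other and compound 2 holds no clearly separate place. Compound 3 (`COc1cc(/C=C/C(=O)/C=C/c2nc(C)c(C)nc2C)cc(OC)c1OC`) differs from compound 2 by one change, methoxy in place of hydrogen on an aromatic carbon. Among the compounds with values here, no measured step adds such a group to the ring. Within the data shown here, the only measured step is a different change, methyl in place of hydrogen on an oxygen on an aromatic ring (a 1.7-fold higher number from compound 1 to compound 2 (0.24 log units; within the scatter)) and it stays within the scatter. It offers only weak guidance, and no shift beyond the scatter is expected. The estimated change is a 1.2-fold lower number from compound 2 to compound 3 (0.07 log units; within the scatter) in this assay and no direction is firmly expected. Compound 3 is expected at 3200 nM with an estimated range of 1200 nM to 8500 nM as its likely span.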

Compound 3, half-maximal inhibitory concentration: 1600 nM
Beside the measured number, compound 3's estimate is 2.0-fold (0.30 log units) above it; the range from low to high includes it.
By their numbers in this assay, from the lowest: compounds 3, 1 and 2 (each within the scatter of the next, the first and the last beyond it).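

In this assay, methoxy in place of hydrogen on an aromatic carbon, ortho to a methoxy group and meta to a large group, gives a 2.4-fold lower number from compound 2 to compound 3 (0.37 log units; beyond the scatter), a modest shift but one beyond the scatter. Within the data shown here, the earlier change, on an oxygen of the same ring, gave a 1.7-fold higher number from compound 1 to compound 2 (0.24 log units; within the scatter) and stayed within the scatter, so this aromatic carbon is the first place where a single change moves the number clearly. Nothing in the data at hand accounts for this shift.

Only methoxy is shown at this position, so it remains open whether an amine or a carboxylic acid there would move the number in the same direction. From the compounds shown here alone, it also remains open whether the shift depends on the methoxy groups already on the ring.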